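Changing the Chlorinated Aryl Group of Compound 1

This account rests on a few compounds, and the source may have more. Where it says the series, first, only, none or still open, it means among the compounds named here.

Among the measured compounds shown here, in a functional assay on BGC-823 cells (Homo sapiens) for inhibition, read by MTT assay, with a stated time of 72 h (a lower number here means a stronger inhibitor, a higher number a weaker inhibitor), compound 1 (`Cc1cc(N2CC[C@@H](C)[C@@H](N(C)c3ncnc4[nH]ccc34)C2)n2nc(SCc3ccc(Cl)cc3)nc2n1`) gives 26300 nM, the only actual number so far. Compound 2 (`C[C@@H]1CCN(c2cc(-c3ccccc3)nc3ncnn23)C[C@@H]1N(C)c1ncnc2[nH]ccc12`) reads > 100000 nM, which is a limit of the assay. Compound 3 (`Cc1nc2nc(SCc3ccc(Cl)cc3)nn2c(N2CC[C@@H](C)[C@@H](N(C)c3ncnc4[nH]ccc34)C2)c1C`) reads > 100000 nM, also a limit. Compound 4 (`Cc1cc(N2CC[C@@H](C)[C@@H](N(C)c3ncnc4[nH]ccc34)C2)n2nc(SCc3csc4ccc(Cl)cc34)nc2n1`) carries 5-chloro-1-benzothiophen-3-yl in place of 4-chlorophenyl on a saturated chain carbon bound to a sulfur. For the measured compounds named here, the one measured step is an at least 3.8-fold higher number from compound 1 to compound 3 (0.58 log units; beyond the scatter), made by methyl in place of hydrogen on an aromatic carbon, a different place from this change. It therefore gives only weak guidance, and (the limit of > 100000 nM in this assay, at which 2 of the 3 values shown sit). No step beyond the scatter is expected, in either direction. The estimated step is a 1.1-fold lower number from compound 1 to compound 4 (0.02 log units; within the scatter). Compound 4 is expected at 25000 nM, within a range of 7000 nM to 90000 nM.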

Compound 4, half-maximal inhibitory concentration: > 100000 nM
Compound 4 ended at the assay's limit (the forecaster's own chance of this, stated with the estimate: 25%); middle value at least 4.0-fold (0.60 log units) from the limit.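

In this assay, among the compounds shown here, this is the first measured change at the saturated chain carbon bound to a sulfur, and 5-chloro-1-benzothiophen-3-yl in place of 4-chlorophenyl gives an at least 3.8-fold higher number from compound 1 to compound 4 (0.58 log units; beyond the scatter). So keeping a chlorinated aryl group here does not by itself preserve the activity of compound 1. Compound 4 reads > 100000 nM, a limit, so the true size of this step cannot be read: the limit of > 100000 nM in this assay, at which 3 of the 4 values shown sit.

Going by these compounds, whether a phenyl without chlorine, a pyridyl group or a 4-methoxyphenyl at this place would match compound 1 at 26300 nM stays open.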